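Thioamide and Smaller Ring in Place of the Cyclohexyl Amide

The source may report more compounds than this note shows. Statements on the series, on what has been measured and on what is new or still open speak of the compounds shown alone.

Compound 1 `Nc1sc(-c2ccc(Cl)cc2)c(-c2ccc(Cl)cc2)c1C(=O)NC1CCCCC1`: 7300 nM
Compound 2 `Nc1sc(-c2ccc([N+](=O)[O-])cc2)c(-c2ccc(Cl)cc2)c1C(=O)NC1CCCCC1`: 25900 nM

In a functional assay on PC-3 cells (Homo sapiens) for cytotoxicity, read by sulforhodamine B assay, with a stated time of 72 h (on this read-out higher numbers stand for weaker inhibition and lower numbers for stronger inhibition), compound 1 gives 7300 nM, the lowest of the two numbers shown, and compound 2 gives 25900 nM. For the measured compounds named here, the only measured step, a 3.5-fold higher number from compound 1 to compound 2 (0.55 log units; beyond the scatter), concerns a nitro in place of chloro and has no bearing on compound 3 `Nc1sc(-c2ccc(Cl)cc2)c(-c2ccc(Cl)cc2)c1C(=S)NC1CCCC1`, whose change is a group of 8 heavy atoms (6 carbon, 1 nitrogen, 1 sulfur; one five-membered non-aromatic ring of carbon only) in place of a group of 9 heavy atoms (7 carbon, 1 nitrogen, 1 oxygen; one six-membered non-aromatic ring of carbon only), on an aromatic carbon. Going by the values given here, no measured step speaks to this change, so the step expected is a 1.0-fold lower number from compound 1 to compound 3 (0.02 log units; within the scatter), none beyond the scatter, with wide uncertainty. Compound 3 is therefore estimated at 7000 nM, within a range of 2000 nM to 25000 nM.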

Compound 3, half-maximal inhibitory concentration: 29000 nM
Compound 3: middle estimate off by 4.1-fold (0.62 log units), on the low side; measured number above the stated range.
By their numbers in this assay, from the lowest: compound 1; then compounds 2 and 3 (each within the scatter of the next).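

This position on the shared core does respond to change in this assay: replacing the cyclohexylcarbamoyl group with the sulfur-bearing group on a five-membered ring weakens inhibition (a 4.0-fold higher number from compound 1 to compound 3 (0.60 log units; beyond the scatter)). The swap alters two things at once, oxygen to sulfur and six-membered ring to five-membered ring, so the step cannot be divided between them. No measurement here gives a cause for the step.

The compounds shown leave open which alteration carries the step, since neither the cyclopentyl amide nor the cyclohexyl thioamide stands among them. As far as these compounds go, how an open-chain group, such as an n-butyl amide, would fare here also remains open.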